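This account rests on a few compounds, and the source may have more. Where it says the series, first, only, none or still open, it means among the compounds named here.

Measured so far:
Compound 1 `Sc1nnc(COc2ccc(-c3ccccc3)cc2)n1-c1ccc(Br)cc1`, which gives 31.8% in a functional assay on the whole organism (strain Wistar) for inhibition, with Rattus norvegicus as the target, read by paw edema, with a stated time of 3 h, at a dose of 10 mg/kg by the oral route; a lower number here means less inhibition, a higher number more inhibition at the dose given (going by the name of the read-out).
Compound 2 `Fc1ccc(-n2c(S)nnc2COc2ccc(-c3ccccc3)cc2)cc1`, which gives 75% in this assay.
Compound 3 `Brc1ccc(Nc2nnc(COc3ccc(-c4ccccc4)cc3)s2)cc1`, which gives 63.6% in this assay.

Compound 1 and compound 2 share a core and differ in one place: fluoro in place of bromo on an aromatic carbon. That single swap is accompanied by a number 43.2 percentage points higher from compound 1 to compound 2 (beyond the scatter) in this assay, a large step. Compound 3 is built on a different core, and the difference between the two cores is not broken down here; compound 3 stands well above compound 1 and somewhat below compound 2 in this assay.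

Compound 4 `Fc1ccc(Nc2nnc(COc3ccc(-c4ccccc4)cc3)s2)cc1` is the unmeasured partner of compound 3. It differs from compound 3 by fluoro in place of bromo on an aromatic carbon, the same change that separates compound 1 from compound 2, made at a place described in the same words. A step in the same direction is therefore expected, but a smaller one than the earlier step, because compound 3 already gives 63.6% and a percentage read-out leaves less room above it. The expected step is a number 14.4 percentage points higher from compound 3 to compound 4 (beyond the scatter). For compound 4 the estimate in this assay is 78%, with a likely range from 60% to 94%.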

Compound 4, a percentage reported as inhibition, in the whole organism at one dose (the size of the read-out at that dose, not a potency): 27.3%
Compound 4: the middle estimate sits 50.7 percentage points above what was measured; measured number below the stated range.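

The change of bromo to fluoro goes with a number 36.3 percentage points lower from compound 3 to compound 4 (beyond the scatter) in this assay, so its result on one core did not predict its result on the other. The two steps run in opposite directions, and the gap between them is wider than repeated measurements would explain: the same change on two cores in this assay, a number 43.2 percentage points higher (beyond the scatter) from compound 1 to compound 2 and a number 36.3 percentage points lower (beyond the scatter) from compound 3 to compound 4, 79.5 percentage points apart, beyond the scatter of two such steps

This shows that, for these two pairs, the outcome of the swap depends on the core that carries it. It does not show which part of the cores is responsible, and two pairs tested at a single dose give no rule for any further core.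

The compounds shown leave open how other groups in the same place, such as chloro, methyl or an amine, would behave on each core, and whether they would also split the two cores apart. They also leave open whether the same opposite steps would appear at another dose or reading time.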